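The source may hold more compounds than are shown below. What is called first, only, known or untested is meant among the compounds shown, and "the series" means these compounds.

Measured so far:
compound 1 `C/C(=N/NC(=O)Nc1nc(-c2ccc(C)cc2)cc(-c2ccc(F)cc2)n1)c1ccc([N+](=O)[O-])cc1` gives 100 mg/kg
compound 2 `C/C(=N/NC(=O)Nc1nc(-c2ccc(C)cc2)cc(-c2ccc(F)cc2)n1)c1ccc(Cl)cc1` gives 30 mg/kg
compound 3 `COc1ccc(-c2cc(-c3ccc(Cl)cc3)nc(NC(=O)N/N=C\c3ccc([N+](=O)[O-])cc3)n2)cc1OC` gives 30 mg/kg

All three values come from a functional assay on the whole organism (strain Albino) with Mus musculus as the target, with a stated time of 0.5 h; a lower number here means that less compound is needed, a higher number that more compound is needed for the effect. Compound 1 stands at the highest of the three numbers; both compound 2 and compound 3 lie beyond the scatter below it, and those two sit at the same value. For the measured compounds named here, the one single-point step measured, a 3.3-fold lower number from compound 1 to compound 2 (0.52 log units; beyond the scatter), concerns a different part of the molecule from the one that changes here.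

Compound 4 `C/C(=N/NC(=O)Nc1nc(-c2ccc(C)cc2)cc(-c2ccc(Cl)cc2)n1)c1ccc([N+](=O)[O-])cc1` differs from compound 1 by chloro in place of fluoro on an aromatic carbon; the same difference, cut one bond further out, reads 4-fluorophenyl to 4-chlorophenyl. Going by the values given here, no measured pair isolates this exchange, so the step from compound 1 to compound 2 is only an indirect guide, and compound 3, which also carries a 4-chlorophenyl group on its core, differs in several other places at once. Expected therefore is a small step in this assay, if any, in the lower direction, estimated as a 1.4-fold lower number from compound 1 to compound 4 (0.15 log units; within the scatter). Compound 4 is expected to give 70 mg/kg, with a range from 30 mg/kg to 150 mg/kg.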

Compound 4, dose for half-maximal effect: 100 mg/kg
Compound 4: the middle estimate sits 1.4-fold (0.15 log units) below what was measured, within the range that was stated.
By their numbers in this assay, from the lowest: compounds 2 and 3 (each within the scatter of the next); then compounds 1 and 4 (each within the scatter of the next).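

For the compounds shown here, compound 1 and compound 4 form the first pair that isolates this position on the 4-fluorophenyl ring. In this assay, placing chloro instead of fluoro on this aromatic carbon, para to a large group, gives no change at the digits printed from compound 1 to compound 4 (within the scatter), so this position tolerates either halogen in the setting of these two compounds, where the nitro group stays in place. The data shown offer no measurement that accounts for this outcome.

From the compounds shown here alone, with only two halogens compared here, it remains open what an amine or a carboxylic acid on this same carbon would do to the dose needed. Also unresolved is whether the exchange of fluoro for chloro would read the same in compound 2, which carries chloro in place of the nitro group.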